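A few compounds are considered here, and "the series" means these few. Any claim that something is new, unique, unknown or untested is made for them only; others in the source may bear on it.

Compound 3 `CCCCN1CCC(C(=O)Nc2ccc(CNc3nc(N(C)C)nc4cc(C)ccc34)cc2)CC1` is measured in a functional assay on SV5A8 cells (Homo sapiens) for cytotoxicity (on this read-out lower numbers stand for stronger inhibition and higher numbers for weaker inhibition), only as a limit, where compound 3 gives > 10500 nM. The other two members sit likewise at limits. Compound 1 `Cc1ccc2c(NCc3ccc(NC(=O)C4CCN(Cc5ccc(F)cc5)CC4)cc3)nc(N(C)C)nc2c1` gives > 4820 nM in this assay, a limit. Compound 2 `Cc1ccc2c(NCc3ccc(NC(=O)C4CCN(Cc5ccc(Cl)cc5)CC4)cc3)nc(N(C)C)nc2c1` gives > 3180 nM in this assay, also a limit. Compound 4 `Cc1ccc2c(NCc3ccc(NC(=O)C4CCN(Cc5ccc(F)cc5Cl)CC4)cc3)nc(N(C)C)nc2c1` carries the change (2-chloro-4-fluorophenyl in place of propyl on a saturated chain carbon bound to an amine nitrogen in a ring). The nearest measured steps, a step that the two limits leave unreadable from compound 1 to compound 3 and a step that the two limits leave unreadable from compound 2 to compound 3, are both left unreadable because every value involved is a limit (the limit of > 10500 nM in this assay, at which 1 of the 3 values shown sits, (the limit of > 3180 nM in this assay, at which 1 of the 3 values shown sits), (the limit of > 4820 nM in this assay, at which 1 of the 3 values shown sits)); the step that the two limits leave unreadable from compound 1 to compound 2 is unreadable for the same reason. No size or direction can be read for the step to compound 4, so only weak inhibition is expected, with an at least 1.1-fold lower number from compound 3 to compound 4 (0.06 log units; that floor lies within the scatter) taken as roughly none. Compound 4 is therefore estimated at 9000 nM, within 3000 nM to 30000 nM, most likely reported again as a limit.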

Compound 4, half-maximal inhibitory concentration: > 5910 nM
Compound 4: no number, only a limit; the forecaster's own chance of this, stated with the estimate: 85%; the middle value does not contradict the limit.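

For the compounds shown here, compounds 1, 2, 3 and 4 all stand only as limits in this assay, so no step among them can be read. The compounds shown leave open whether the groups on the saturated chain carbon bound to an amine nitrogen in a ring shift this read-out at all.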